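Working notes: compound 4 expected from three measured analogues

A few compounds are considered here, and "the series" means these few. Any claim that something is new, unique, unknown or untested is made for them only; others in the source may bear on it.

Measured so far:
compound 1 `CCOc1ccccc1-c1ccc(-c2nc3cnccc3c(N[C@H](CC)C(N)=O)c2C#N)cc1` — 151 nm/s
compound 2 `CC[C@@H](Nc1c(C#N)c(-c2ccc(-c3cccc(OC)c3)cc2)nc2cnccc12)C(N)=O` — 104 nm/s
compound 3 `CC[C@@H](Nc1c(C#N)c(-c2ccc(Br)cc2)nc2cnccc12)C(N)=O` — 202 nm/s

In an ADME assay on Caco-2 cells (Homo sapiens) for permeability, read by LC-MS, in the apical to basolateral direction, with a stated time of 2 h, tested at 2 uM (on this read-out higher numbers stand for higher permeability and lower numbers for lower permeability), compound 3 stands at the top of the three numbers, yet the two measured steps into it, a 1.3-fold higher number from compound 1 to compound 3 (0.13 log units; within the scatter) and a 1.9-fold higher number from compound 2 to compound 3 (0.29 log units; within the scatter), both lie within the scatter, as does a 1.5-fold lower number from compound 1 to compound 2 (0.16 log units; within the scatter). Nothing among these three separates a bromo from an aryl group on that aromatic carbon beyond repeat-measurement noise.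

Compound 4 `CC[C@@H](Nc1c(C#N)c(-c2ccc(-c3cccc(C)c3F)cc2)nc2cnccc12)C(N)=O` is not yet measured. Its change from compound 3: 2-fluoro-3-methylphenyl in place of bromo on an aromatic carbon. This is the reverse of the two steps that bear on it, a 1.3-fold higher number from compound 1 to compound 3 (0.13 log units; within the scatter) and a 1.9-fold higher number from compound 2 to compound 3 (0.29 log units; within the scatter), which removed an aryl group in favour of bromo. Because a 1.3-fold higher number from compound 1 to compound 3 (0.13 log units; within the scatter) and a 1.9-fold higher number from compound 2 to compound 3 (0.29 log units; within the scatter) in this assay were both small, the aryl group entering here is expected to move the number by no more than the scatter, if anything slightly downward toward the values of compound 1 and compound 2. Compound 4 is therefore estimated at 130 nm/s, range 65 nm/s to 260 nm/s, an expected step of a 1.6-fold lower number from compound 3 to compound 4 (0.19 log units; within the scatter).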

Compound 4, apparent permeability: 47 nm/s
Compound 4: the middle estimate sits 2.8-fold (0.44 log units) above what was measured, outside the stated range (below it).
By their numbers in this assay, from the lowest: compound 4; then compounds 2, 1 and 3 (each within the scatter of the next).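

Among the compounds shown here, at this aromatic carbon, para to a large group, the earlier steps in this assay all lay within the scatter, whereas 2-fluoro-3-methylphenyl in place of bromo gives a 4.3-fold lower number from compound 3 to compound 4 (0.63 log units; beyond the scatter). An aryl group at this position therefore does not settle the number by itself: the same entering group also gives a 2.2-fold lower number from compound 2 to compound 4 (0.34 log units; beyond the scatter) and a 3.2-fold lower number from compound 1 to compound 4 (0.51 log units; beyond the scatter), although 3-methoxyphenyl and 2-ethoxyphenyl each stand within the scatter of bromo. No measured evidence is available to explain these differences.

The compounds shown do not separate the fluoro from the methyl of the entering ring, so neither can be assigned the steps. On these data alone, how an amine or a carboxylic acid on that ring, or a longer alkyl chain in its place, would read in this assay remains open.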